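A few compounds are considered here, and "the series" means these few. Any claim that something is new, unique, unknown or untested is made for them only; others in the source may bear on it.

Measured so far:
compound 1, `CCCCCC/N=C(\C)c1c(O)c2ccccc2oc1=O`: 2900 nM
compound 2, `C/C(=N\CC1CCCCC1)c1c(O)c2ccccc2[nH]c1=O`: a limit only, >= 100000 nM

Among the compounds with values here, compound 1 holds the only number recorded for the series in an assay on isolated protein for inhibition of myosin-2 (Bos taurus), read by spectrophotometry, with a stated time of 24 min; on this read-out lower numbers stand for stronger inhibition and higher numbers for weaker inhibition; the one other value shown is a limit rather than a number. For compound 2 the read-out in this assay is a limit of the assay, >= 100000 nM, which is the limit of >= 100000 nM in this assay, at which 1 of the 2 values shown sits. Of this pair nothing more can be said than that compound 1 gives a number and compound 2 only a limit.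

Compound 3, `C/C(=N\CCO)c1c(O)c2ccccc2oc1=O`, is not yet measured. It differs from compound 1 by hydroxy in place of butyl on a saturated chain carbon, two bonds along the chain from a double-bonded nitrogen. Within the data shown here, no step between two measured compounds is available to size this change, so the expectation rests on the change itself and on the value of compound 1 in this assay. The expected step, a 5.2-fold higher number from compound 1 to compound 3 (0.71 log units; beyond the scatter), is toward weaker inhibition in this assay and beyond the usual scatter. Compound 3 is accordingly estimated at 15000 nM in this assay, with a range from 4000 nM to 60000 nM; a limit instead of a number is also possible.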

Compound 3, half-maximal inhibitory concentration: 92000 nM
For compound 3 the middle estimate is 6.1-fold (0.79 log units) below the measured one; the measured number lies above the stated range.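

In this assay, within the data shown here, hydroxy in place of butyl on a saturated chain carbon, two bonds along the chain from a double-bonded nitrogen, gives a 32-fold higher number from compound 1 to compound 3 (1.50 log units; beyond the scatter), the first step that can be sized. Inhibition at this chain is therefore not indifferent to the change from hexyl to 2-hydroxyethyl: on the shared core of this single pair, the step is large and toward weaker inhibition, although no wider pattern can be drawn from one pair. Compound 2 remains a limit of the assay and enters no step: the limit of >= 100000 nM in this assay, at which 1 of the 3 values shown sits.

The pair changes chain length and adds hydroxy in a single move, and the data do not separate the loss of butyl from the arrival of hydroxy. On these data alone, a plain ethyl chain and a hexyl chain ending in hydroxy would divide the step into those two parts, while a longer chain than hexyl, or an amine or a carboxylic acid at the chain end, remains open on this core.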